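Cyclopropyl for Ethyl on the Amide Nitrogen

The compounds below may be only part of what the source reports. "The series", "measured", "known", "first", "only" and "open" are said of these compounds alone.

Measured so far:
compound 1, `CNC(=O)/C=C1\CCc2ccc(Br)cc21`, 53%
compound 2, `NC(=O)/C=C1\CCc2cc(Cl)ccc21`, 29%
compound 3, `CCNC(=O)/C=C1\CCc2ccc(F)cc21`, 63%

Of the compounds shown here, three sharing one core have been tested in a functional assay on the whole organism with Rattus norvegicus as the target, at a dose of 20 mg/kg by the oral route; on this read-out higher numbers stand for more inhibition at the one dose given (going by the name of the read-out) and lower numbers for less inhibition. Compound 1, with its methylamide, gives 53%. Compound 2, carrying a primary amide, gives 29%. Compound 3, the ethylamide, gives 63%, the highest of the three numbers; compound 1 lies within the usual scatter of it, while compound 2 lies well beyond. No two of these compounds differ in only one place, so nothing can be said about any single change among them.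

Compound 4, `O=C(/C=C1\CCc2ccc(F)cc21)NC1CC1`, has not yet been measured. It differs from compound 3 in one place: cyclopropyl in place of ethyl on an amide-type nitrogen. Both groups carry no donors or acceptors and no charge, and the change stays on the amide nitrogen. Among the compounds with values here, with no single-place step among the measured compounds to lean on, the expectation is cautious: compound 4 is expected to land close to compound 3, with a step of about a number 3 percentage points lower from compound 3 to compound 4 (within the scatter) in this assay, which is no step beyond the scatter. For compound 4 the estimated value is 60%, in a range from 40% to 78%.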

Compound 4, a percentage reported as inhibition, in the whole organism at one dose (the size of the read-out at that dose, not a potency): 7%
Compound 4: the middle estimate sits 53 percentage points above what was measured; the measured number lies below the stated range.
By their numbers in this assay, from the lowest: compound 4; then compound 2; then compounds 1 and 3 (each within the scatter of the next).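

Within the data shown here, the first comparison that differs in only one place shows that the group on the amide-type nitrogen can, by itself, decide the outcome in this assay: replacing ethyl with cyclopropyl gives a step of a number 56 percentage points lower from compound 3 to compound 4 (beyond the scatter) with the rest of the structure unchanged. The earlier compounds shown here could not show this, since each differs from the others in more than one place and their spread could not be assigned to the amide nitrogen alone. The two groups have the same counts of hydrogen-bond donors and acceptors and no net charge, and differ in the count of carbons and in the three-membered ring, yet nothing measured here says what lies behind the step.

The compounds shown leave open whether the fall belongs to the ring itself or would also come with a propyl or isopropyl group on the same nitrogen, or with a larger ring such as cyclobutyl. They also leave open whether cyclopropyl would give a similar step on the bromine-bearing core of compound 1.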